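The source may hold more compounds than are shown below. What is called first, only, known or untested is meant among the compounds shown, and "the series" means these compounds.

Measured so far:
compound 1 `O=C(Nc1ccccc1)c1cccc(/C=C2\CC(=O)N(c3ccccc3)C2=O)c1` gives > 100000 nM
compound 2 `O=C(Nc1ccc(OC(F)F)cc1)c1cccc(/C=C2\CC(=O)N(c3ccccc3)C2=O)c1` gives > 100000 nM

Both values come from an ADME assay on SW480 cells (Homo sapiens) for cytotoxicity, read by MTT assay, with a stated time of 72 h; a lower number here means a stronger inhibitor, a higher number a weaker inhibitor. In this assay compound 1 gives > 100000 nM, which is a limit of the assay rather than a number. In this assay compound 2 likewise gives > 100000 nM, again a limit and not a number. Within the data shown here, the one measured step, a step that the two limits leave unreadable from compound 1 to compound 2, therefore cannot be sized; the two limits only show that neither compound reached a measurable number, as the limit of > 100000 nM in this assay, at which 2 of the 2 values shown sit, records.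

Compound 3 `O=C(Nc1ccc(F)cc1)c1cccc(/C=C2\CC(=O)N(c3ccccc3)C2=O)c1` has not yet been measured. It differs from compound 2 in one place: fluoro in place of difluoromethoxy on an aromatic carbon.

The step from compound 1 to compound 2 is the only one that bears on this change, and it is unreadable. With both measured compounds sitting at the limit of this assay, the step from compound 2 to compound 3 is expected to stay within the scatter, with a step that the limit leaves unreadable from compound 2 to compound 3 as the estimate. Compound 3 is therefore expected to give about 150000 nM in this assay, in a range from 50000 nM to 500000 nM, most likely reported again as a limit.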

Compound 3, half-maximal inhibitory concentration: > 100000 nM
Compound 3 gave a limit, no number; the forecaster's own chance of this, stated with the estimate: 85%; the middle value is on the limit's open side.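

In this assay compound 3 gives > 100000 nM, again a limit and not a number. Among these compounds, no step among compound 1, compound 2 and compound 3 can therefore be read. The compounds shown leave open whether these three differ at all in this test, and whether any change to them would give a measurable number, with all of them sitting at one shared value: the limit of > 100000 nM in this assay, at which 3 of the 3 values shown sit.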